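The compounds below may be only part of what the source reports. "The series", "measured", "known", "first", "only" and "open" are said of these compounds alone.

Values in an assay on a cell-free system (plasma) for inhibition of Dipeptidyl peptidase 4 (Rattus norvegicus), read by fluorescence, with a stated time of 60 min; a lower number here means a stronger inhibitor, a higher number a weaker inhibitor:
- compound 1 `Cc1cc(N2CCN([C@@H]3CN[C@H](C(=O)N4CCSC4)C3)CC2)n(-c2ccc(F)cc2)n1`: 2.3 nM
- compound 2 `Cc1cc(N2CCN([C@@H]3CN[C@H](C(=O)N4CCSC4)C3)CC2)n(-c2cccc(F)c2)n1`: 0.49 nM
- compound 3 `Cc1cc(N2CCN([C@@H]3CN[C@H](C(=O)N4CCSC4)C3)CC2)n(-c2ccc(Cl)cc2)n1`: 2.9 nM

Compound 3 carries the highest number of the three. Its gap to compound 1 is small, the step of a 1.3-fold higher number from compound 1 to compound 3 (0.10 log units; within the scatter) lying within the scatter, while the step of a 5.9-fold higher number from compound 2 to compound 3 (0.77 log units; beyond the scatter) lies beyond it.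

Compound 4 `Cc1cc(N2CCN([C@@H]3CN[C@H](C(=O)N4CCSC4)C3)CC2)n(-c2ccc(C#N)cc2)n1` differs from compound 3 by cyano in place of chloro on an aromatic carbon. Among the measured compounds shown here, only one measured step bears on this position: a 1.3-fold higher number from compound 1 to compound 3 (0.10 log units; within the scatter), a swap of one halogen for another there, which stayed within the scatter. For the measured compounds named here, no measured compound carries a cyano group, so the bearing of this particular change is untested. On that basis compound 4 is expected to stay close to compound 3 in this assay, with the expected step of a 1.2-fold lower number from compound 3 to compound 4 (0.06 log units; within the scatter) not beyond the scatter. The estimate for compound 4 is 2.5 nM, with a range from 0.8 nM to 8 nM.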

Compound 4, half-maximal inhibitory concentration: 13 nM
For compound 4 the middle estimate is 5.2-fold (0.72 log units) below the measured one; measured number above the stated range.
By their numbers in this assay, from the lowest: compound 2; then compounds 1 and 3 (each within the scatter of the next); then compound 4.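

On the aromatic carbon para to a large group, the identity of the substituent matters: the halogen swap stayed within the scatter, but cyano in place of chloro gives a 4.5-fold higher number from compound 3 to compound 4 (0.65 log units; beyond the scatter) and cyano in place of fluoro gives a 5.7-fold higher number from compound 1 to compound 4 (0.75 log units; beyond the scatter). 4-Cyanophenyl in place of 3-fluorophenyl gives a 27-fold higher number from compound 2 to compound 4 (1.42 log units; beyond the scatter), the largest step in the series. No evidence at hand accounts for the nitrile parting from the halogens.

Open, from the compounds shown here alone, is how an amine or a methoxy group on this same carbon would compare with chloro and cyano.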